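The source may report more compounds than this note shows. Statements on the series, on what has been measured and on what is new or still open speak of the compounds shown alone.

Measured so far:
Compound 1, `CC[C@@H]1C(=O)N(C)c2cnc(-n3ccnc3-c3ccccc3)nc2N1C1CCCC1`: 0%
Compound 2, `CC[C@@H]1C(=O)N(C)c2cnc(-n3ccnc3-c3ccccc3)nc2N1[C@H]1CCOC1`: 17%

Of the compounds shown here, two have been tested in an ADME assay on microsomes from liver (Homo sapiens) for metabolic stability, with a stated time of 30 min, tested at 1 uM; a lower number here means that less of the compound is left, a higher number that more of the compound is left. In this assay compound 1 gives 0%, meaning none of it is left after the stated time. Compound 2, which carries an oxolan-3-yl in place of the cyclopentyl on a nitrogen on an aromatic ring in a ring, gives 17%. Going by the values given here, the one measured step is a number 17 percentage points higher from compound 1 to compound 2 (beyond the scatter), which places compound 2 highest of the two numbers, with compound 1 as its only neighbour.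

The next compound is compound 3, `CC[C@@H]1C(=O)N(C)c2cnc(-n3ccnc3-c3ccccc3)nc2N1[C@@H]1CCOC1`. Compared with compound 2: the two compounds have the same atoms and bonds and differ only in configuration as drawn: 1 of 2 stereo elements differ; a stereocentre at a saturated ring carbon is drawn S in compound 2 and R in compound 3. Among the compounds with values here, no measured step here involves only a change of configuration, so the single measured step, which swaps one group for another, does not bear directly on this change; it shows only that the oxolan-3-yl group itself matters for the reading. With the same atoms and bonds in both compounds, the expectation is for no step beyond the scatter, a number 2 percentage points lower from compound 2 to compound 3 (within the scatter). Compound 3 is therefore estimated at 15%, with a likely range from 2% to 35%.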

Compound 3, percent of the compound remaining: 10%
Compound 3: middle estimate off by 5 percentage points, on the high side; the range from low to high includes it.
By their numbers in this assay, from the lowest: compounds 1, 3 and 2 (each within the scatter of the next, the first and the last beyond it).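

In this assay, the configuration at the saturated ring carbon of the oxolan-3-yl group can now be read alone, and it gives a number 7 percentage points lower from compound 2 to compound 3 (within the scatter), so the two drawn forms cannot be told apart at this position. The comparison is a clean one, with nothing else to account for the small difference: the fact that compounds 2 and 3 differ only in the configuration as drawn

The swap of cyclopentyl for oxolan-3-yl also looks less secure than it did, since the new form gives a number 10 percentage points higher from compound 1 to compound 3 (within the scatter), while the earlier step reads a number 17 percentage points higher from compound 1 to compound 2 (beyond the scatter). Only one of the two drawn forms therefore stands clear of the cyclopentyl compound, even though those two forms do not stand clear of each other, so the benefit of the oxolan-3-yl group rests on a narrow margin.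

From the compounds shown here alone, how a different group on this nitrogen, such as oxan-4-yl, an amine such as piperidin-4-yl or a longer chain, would read remains open. Going by these compounds, it is also open whether replacing the phenyl or the ethyl elsewhere on the shared core would move the reading further than any change at this nitrogen.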